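Trimming Isopentyl to Butyl on Compound 3

The source may report more compounds than this note shows. Statements on the series, on what has been measured and on what is new or still open speak of the compounds shown alone.

For the measured compounds named here, in a functional assay on K562 cells (Homo sapiens) for inhibition, read by fluorescence, with a stated time of 72 h (a lower number here means a stronger inhibitor of growth, a higher number a weaker inhibitor of growth), three compounds built on a shared core have numbers so far. Compound 1 (`CCCCn1cnc2c(NCc3cccc(Cl)c3)nc(N[C@H]3CC[C@H](N)CC3)nc21`) gives 4300 nM, compound 2 (`CCCCn1cnc2c(Nc3cc(OC)cc(OC)c3)nc(N[C@H]3CC[C@H](N)CC3)nc21`) gives 2400 nM, and compound 3 (`CC(C)CCn1cnc2c(Nc3ccccc3)nc(N[C@H]3CC[C@H](N)CC3)nc21`) gives 3500 nM, which lies within the scatter of both others. Compound 4 (`CCCCn1cnc2c(Nc3ccccc3)nc(N[C@H]3CC[C@H](N)CC3)nc21`) departs from compound 3 in one place: hydrogen in place of methyl on a saturated chain carbon bound to two saturated chain carbons. This is hydrogen in place of methyl on a saturated chain carbon bound to two saturated chain carbons, so isopentyl becomes butyl.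

Going by the values given here, no measured step tests this chain directly. The only one, a 1.8-fold lower number from compound 1 to compound 2 (0.25 log units; within the scatter), concerns the group on a nitrogen on an aromatic ring, with butyl present on both sides, and it stays within the scatter. Compound 1 and compound 2 carry butyl yet differ from compound 3 elsewhere too, so their values offer only loose guidance. No step beyond the scatter is expected, and the estimate amounts to a 1.2-fold lower number from compound 3 to compound 4 (0.07 log units; within the scatter). For compound 4 the expected value is 3000 nM, with an estimated range from 1500 nM to 6000 nM.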

Compound 4, concentration for 50% growth inhibition: 3200 nM
Compound 4: the middle estimate sits 1.1-fold (0.03 log units) below what was measured; the range from low to high includes it.
By their numbers in this assay, from the lowest: compounds 2, 4, 3 and 1 (each within the scatter of the next).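

In this assay, the direct test of this chain gives a 1.1-fold lower number from compound 3 to compound 4 (0.04 log units; within the scatter), so hydrogen in place of methyl on a saturated chain carbon bound to two saturated chain carbons, which turns isopentyl into butyl, leaves no difference that stands clear of the scatter. Compound 4 also links the phenyl analogue with butyl to the two other butyl compounds, with a 1.3-fold higher number from compound 2 to compound 4 (0.12 log units; within the scatter) and a 1.3-fold lower number from compound 1 to compound 4 (0.13 log units; within the scatter), and both steps lie within the scatter, so none of these three groups on a nitrogen on an aromatic ring separates from the others here. No supporting evidence accounts for these results.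

As far as these compounds go, only isopentyl and butyl are compared directly on this chain, so a longer chain such as hexyl, or a chain ending in an amine or a carboxylic acid, remains open. From the compounds shown here alone, whether isopentyl would read the same alongside 3,5-dimethoxyphenyl or 3-chlorobenzyl also remains open.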